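Benzoyl in place of phenylsulfonyl on the vinyl nitrile

A few compounds are considered here, and "the series" means these few. Any claim that something is new, unique, unknown or untested is made for them only; others in the source may bear on it.

Compound 2 `N#C/C(=C\c1c(-c2ccccc2)[nH]c2ccccc12)S(=O)(=O)c1ccccc1` is one of two measured compounds. In a functional assay on SK-OV-3 cells (Homo sapiens) for inhibition, read by sulforhodamine B assay, with a stated time of 48 h (on this read-out higher numbers stand for weaker inhibition of growth and lower numbers for stronger inhibition of growth), compound 2 gives 6800 nM. Among the compounds with values here, its neighbour compound 1 `COc1ccc2[nH]c(-c3ccccc3)c(/C=C(\C#N)S(=O)(=O)c3ccccc3)c2c1` gives 7100 nM in this assay, and the two values sit within the scatter of each other; the only measured step, a 1.0-fold lower number from compound 1 to compound 2 (0.02 log units; within the scatter), changed nothing beyond the scatter. Compound 3 `N#C/C(=C\c1c(-c2ccccc2)[nH]c2ccccc12)C(=O)c1ccccc1` differs from compound 2 by benzoyl in place of phenylsulfonyl on a double-bonded chain carbon bound to a double-bonded chain carbon and a triple-bonded carbon. Within the data shown here, no measured step touches this part of the shared core: the one step on record, a 1.0-fold lower number from compound 1 to compound 2 (0.02 log units; within the scatter), concerns a methoxy on the aromatic ring and gives no guidance on swapping the group bound to the vinyl nitrile. Among the measured compounds shown here, with no bearing precedent, compound 3 is expected to stay close to compound 2 in this assay, with a broad range; the estimate for compound 3 is 6500 nM (range 1500 nM to 28000 nM), meaning an expected step of a 1.0-fold lower number from compound 2 to compound 3 (0.02 log units; within the scatter).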

Compound 3, concentration for 50% growth inhibition: 15200 nM
Compound 3: middle estimate off by 2.3-fold (0.37 log units), on the low side; the measured number falls inside the stated range.
By their numbers in this assay, from the lowest: compounds 2 and 1 (each within the scatter of the next); then compound 3.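

In this assay, the group on the double-bonded chain carbon bound to a double-bonded chain carbon and a triple-bonded carbon proves to matter: a 2.2-fold higher number from compound 2 to compound 3 (0.35 log units; beyond the scatter) is a modest step, but the first in this small set to go beyond the scatter. The methoxy step, a 1.0-fold lower number from compound 1 to compound 2 (0.02 log units; within the scatter), gave no such sign, so this place responds where that aromatic carbon did not. Phenylsulfonyl and benzoyl are therefore not interchangeable here, with phenylsulfonyl giving the stronger inhibition of growth of the pair. No measurement at hand accounts for this difference.

From the compounds shown here alone, whether a methyl ester or a primary amide at this place would read like phenylsulfonyl or like benzoyl remains open. So does whether a methoxy on the aromatic carbon would stay as silent alongside benzoyl.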